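A few compounds are considered here, and "the series" means these few. Any claim that something is new, unique, unknown or untested is made for them only; others in the source may bear on it.

Series on a shared core carrying a free hydroxy group on an oxygen on an aromatic ring, read in a functional assay on K562 cells (Homo sapiens) for cytotoxicity, read by MTT assay; a lower number here means a stronger inhibitor, a higher number a weaker inhibitor. Compound 1 `COc1ccc(/C=C/C(=O)c2ccc(OC)c3c2OC(C)(C)C=C3)cc1O` gives 630 nM and stands lowest of the two numbers shown. Compound 2 `COc1ccc(/C=C/C(=O)c2ccc(OC)c3c2OC(C)(C)C=C3)cc1OCC=C(C)C`, with 3-methylbut-2-en-1-yl on that oxygen, gives > 10000 nM, which is a limit of this assay and not a number. Compound 3 `COc1ccc(/C=C/C(=O)c2ccc(OC)c3c2OC(C)(C)C=C3)cc1OCCCN(C)C`, with 3-(dimethylamino)propyl on the same oxygen, gives 2920 nM. The steps from the parent are an at least 15-fold higher number from compound 1 to compound 2 (1.20 log units; beyond the scatter) and a 4.6-fold higher number from compound 1 to compound 3 (0.67 log units; beyond the scatter); between the two substituted compounds the step is an at least 3.4-fold lower number from compound 2 to compound 3 (0.53 log units; beyond the scatter). Compound 4 `COc1ccc(/C=C/C(=O)c2ccc(OC)c3c2OC(C)(C)C=C3)cc1OC(=O)C1CC1` carries cyclopropylcarbonyl in place of hydrogen on an oxygen on an aromatic ring. Both measured replacements of the hydrogen on this oxygen raised the number, one of them only as a limit; a rise is therefore expected here too, of a size between those two. For compound 4 the estimate is 3000 nM, with a range of 800 nM to 15000 nM. This estimate means a step of a 4.8-fold higher number from compound 1 to compound 4 (0.68 log units; beyond the scatter), expected to lie beyond the scatter.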

Compound 4, half-maximal inhibitory concentration: 410 nM
The estimate for compound 4 lay 7.3-fold (0.86 log units) above the measured number; measured number below the stated range.
By their numbers in this assay, from the lowest: compounds 4 and 1 (each within the scatter of the next); then compound 3. At a limit, above all of these: compound 2.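

In this assay, among the compounds shown here, cyclopropylcarbonyl is the first replacement of the hydrogen on this oxygen that stays level with the parent, with a 1.5-fold lower number from compound 1 to compound 4 (0.19 log units; within the scatter) and so a free hydroxy is not needed for a number of this size. Compounds sharing the core separate clearly by the group attached, with a 7.1-fold lower number from compound 3 to compound 4 (0.85 log units; beyond the scatter) as the gap to the 3-(dimethylamino)propyl compound, so the outcome depends on which group enters and not simply on the hydrogen leaving. Compound 2 stands at a limit, and an at least 24-fold lower number from compound 2 to compound 4 (1.38 log units; beyond the scatter) reads as a bound only: the limit of > 10000 nM in this assay, at which 1 of the 4 values shown sits.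

Open, as far as these compounds go, is whether this level number belongs to cyclopropylcarbonyl alone or also holds for a plain acetyl or a benzoyl on the same oxygen. Equally open, from the compounds shown here alone, is how a longer acyl chain or a carboxylic acid there would read.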